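Swapping the thiophene arm of a weak antiproliferative lead

The compounds below may be only part of what the source reports. "The series", "measured", "known", "first", "only" and "open" are said of these compounds alone.

For the measured compounds named here, compound 1, `Cn1c(=O)c(=O)n(C2CCCC2)c2nc(N/N=C/c3cccs3)ncc21`, is the weaker of the two measured members of this small set. In a functional assay on HCT-116 cells (Homo sapiens) for antiproliferative activity, read by MTT assay (a higher number here means a weaker inhibitor, a lower number a stronger inhibitor), compound 1 gives 52600 nM, the highest number recorded. Going by the values given here, its only measured companion is compound 2, `COc1cc(/C=N/Nc2ncc3c(n2)n(C2CCCC2)c(=O)c(=O)n3C)cc(OC)c1OC`, which carries a trimethoxyphenyl arm on the same hydrazone linkage; in this assay compound 2 gives 22900 nM, a lower number whose gap to compound 1 lies beyond the usual scatter. Among the compounds with values here, no single-change step between measured compounds is available, so the comparison rests on these two values alone.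

The unmeasured compound 3, `CSc1ccc(/C=N/Nc2ncc3c(n2)n(C2CCCC2)c(=O)c(=O)n3C)cc1`, differs from compound 1 in one place: 4-(methylsulfanyl)phenyl in place of thiophen-2-yl on a carbon with a double bond to nitrogen. Because compound 2, the only other aryl hydrazone here, gives 22900 nM, a six-membered carbon ring on this carbon appears compatible with a somewhat lower number than compound 1 shows, though nothing more than this single comparison supports that view. The step of a 1.8-fold lower number from compound 1 to compound 3 (0.24 log units; within the scatter) is therefore expected to be small and downward, possibly no larger than the scatter. For compound 3 the expected value in this assay is 30000 nM, with a likely range from 12000 nM to 80000 nM.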

Compound 3, half-maximal inhibitory concentration: 9010 nM
The estimate for compound 3 lay 3.3-fold (0.52 log units) above the measured number; measured number outside the range, below it.
By their numbers in this assay, from the lowest: compound 3; then compound 2; then compound 1.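

In this assay, for the compounds shown here, the change to 4-(methylsulfanyl)phenyl in place of thiophen-2-yl on a carbon with a double bond to nitrogen gives a 5.8-fold lower number from compound 1 to compound 3 (0.77 log units; beyond the scatter), the first single-change step at this position and one that lies beyond the usual scatter. It shows that the number responds clearly to the group at this position, and that the arm need not carry the three methoxy groups of compound 2, which gives 22900 nM, to fall below compound 1: compound 3 gives 9010 nM, the lowest of the three numbers. No independent measurement bears on the reason for this step.

From the compounds shown here alone, the change replaces the ring and introduces the methylsulfanyl group together, so the share of each in the step remains open, and an unsubstituted phenyl ring on the same carbon would separate the two. Going by these compounds, whether the methylsulfanyl group itself matters also remains open, a question that a methoxy group or a chlorine atom in its place, on the otherwise unchanged phenyl ring, could address.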